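This account rests on a few compounds, and the source may have more. Where it says the series, first, only, none or still open, it means among the compounds named here.

Measured compounds:
compound 1, `CC(C(=O)NCc1ccc(C(F)(F)F)cc1N1CCCCCCC1)c1ccc(NS(C)(=O)=O)c(F)c1`: 2.8 nM
compound 2, `CC(C(=O)NCc1ccc(C(F)(F)F)cc1F)c1ccc(NS(C)(=O)=O)c(F)c1`: 68.7 nM

In an assay on CHO cells for antagonist activity at transient receptor potential cation channel subfamily V member 1 (Homo sapiens), read by FLIPR (on this read-out higher numbers stand for weaker inhibition and lower numbers for stronger inhibition), compound 2 gives the highest of the two numbers; its nearest neighbour is compound 1, and the step of a 25-fold higher number from compound 1 to compound 2 (1.39 log units; beyond the scatter) is beyond the scatter. Compound 3, `CC(C(=O)NCc1ccc(C(F)(F)F)cc1-c1cccc(Cl)c1)c1ccc(NS(C)(=O)=O)c(F)c1`, has not yet been measured. It differs from compound 2 by 3-chlorophenyl in place of fluoro on an aromatic carbon, so a large group again enters the position that carried the eight-membered ring in compound 1. Within the data shown here, the only step that bears on this change is a 25-fold higher number from compound 1 to compound 2 (1.39 log units; beyond the scatter), where a large group at this position went with the lower number. Among the measured compounds shown here, a step in the opposite direction is therefore expected from compound 2 to compound 3 in this assay, though not necessarily of the same size, since the entering group is not the one present in compound 1. For compound 3 the estimate is 8 nM, with a range from 2 nM to 35 nM, corresponding to an 8.6-fold lower number from compound 2 to compound 3 (0.93 log units; beyond the scatter).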

Compound 3, inhibition constant: 1 nM
Beside the measured number, compound 3's estimate is 8.0-fold (0.90 log units) above it; measured number below the stated range.
By their numbers in this assay, from the lowest: compound 3; then compound 1; then compound 2.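

In this assay, the low number at this aromatic carbon does not depend on the eight-membered non-aromatic ring of compound 1: 3-chlorophenyl, which carries no nitrogen, also restores it with a 69-fold lower number from compound 2 to compound 3 (1.84 log units; beyond the scatter) on replacing fluoro. The two large groups are not interchangeable either, since a 2.8-fold lower number from compound 1 to compound 3 (0.45 log units; beyond the scatter) is a modest step but lies beyond the scatter, so the identity of the large group still counts at this position. No measurement is at hand that explains either step.

Going by these compounds, it remains open how much of the low number belongs to the chlorine, which a plain phenyl group at the same carbon would separate from the ring itself. Also open, on these data alone, is whether a much smaller group such as dimethylamino or methoxy would already give a number well below that of compound 2.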